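This account rests on a few compounds, and the source may have more. Where it says the series, first, only, none or still open, it means among the compounds named here.

Within the data shown here, compound 1, with the structure `C=C1C(=O)O[C@@H]2[C@@H]1CC[C@H](C)[C@@](O)(C(=O)/C=C/C)[C@H]2OC(=O)/C(C)=C\C`, is one of two compounds measured in a functional assay on KB-V1 cells (Homo sapiens) for cytotoxicity, in the presence of a further agent that is not named here; a lower number here means that less compound is needed, a higher number that more compound is needed for the effect. In this assay compound 1 gives 0.3 ug/mL, the lowest of the two numbers available. Among the measured compounds shown here, the only other compound measured, compound 2 with the structure `C=C1C(=O)O[C@@H]2[C@@H]1C[C@@H](O)[C@H](C)[C@@](O)(C(=O)/C=C/C)[C@H]2OC(=O)/C(C)=C\C`, gives 1.3 ug/mL. For the measured compounds named here, the single step known is a 4.3-fold higher number from compound 1 to compound 2 (0.64 log units; beyond the scatter), and it came from a hydroxy in place of hydrogen on a saturated ring carbon of the shared core.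

Compound 3, with the structure `C=C1C(=O)O[C@@H]2[C@@H]1[C@@H](O)C[C@H](C)[C@@](O)(C(=O)/C=C/C)[C@H]2OC(=O)/C(C)=C\C`, has not yet been measured. It differs from compound 1 by hydroxy in place of hydrogen on a saturated ring carbon. Going by the values given here, the one measured step that bears on this change is a 4.3-fold higher number from compound 1 to compound 2 (0.64 log units; beyond the scatter), where a hydroxy placed on another saturated ring carbon of the same core raised the number beyond the scatter, though only modestly. With a single comparison at a different ring carbon, the expectation for compound 3 is tentative, and a rise of similar size is expected, a 3.3-fold higher number from compound 1 to compound 3 (0.52 log units; beyond the scatter). Compound 3 is therefore estimated to give 1 ug/mL, with a range from 0.3 ug/mL to 3 ug/mL that still allows a value close to that of compound 1.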

Compound 3, concentration for half-maximal effect: 1.7 ug/mL
Compound 3: middle estimate off by 1.7-fold (0.23 log units), on the low side; measured number inside the range.
By their numbers in this assay, from the lowest: compound 1; then compounds 2 and 3 (each within the scatter of the next).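

Putting a hydroxy in place of hydrogen on this saturated ring carbon of the seven-membered ring, next to the ring atom that bears a fused ring, gives a 5.7-fold higher number from compound 1 to compound 3 (0.75 log units; beyond the scatter) in this assay. Alongside a 4.3-fold higher number from compound 1 to compound 2 (0.64 log units; beyond the scatter), this makes two ring carbons of the shared core where the same change goes with a higher number, so the rise is not confined to a single carbon, and no compound shown goes against this within the pair of steps available. Nothing measured here explains the rise at either carbon.

The compounds shown leave open whether the higher number belongs to the hydroxy in particular or would also follow from another group on this carbon, such as a methoxy, an amine or a fluorine atom. Also open, going by these compounds, is whether a hydroxy on the same carbon, pointing the opposite way in space, would give a number closer to that of compound 1, which would show how much the orientation of the group matters in this assay.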